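Series notes: cinnamamide aryl change, compound 3 to compound 4

This account rests on a few compounds, and the source may have more. Where it says the series, first, only, none or still open, it means among the compounds named here.

The shared core of compound 3 `CCCc1cc(N)c2cc(NC(=O)/C=C/c3ccccc3Cl)ccc2n1` carries a 2-chlorophenyl group; in an assay on isolated protein for displacement of a labelled ligand from melanin-concentrating hormone receptor 1 (Homo sapiens) (on this read-out higher numbers stand for weaker inhibition and lower numbers for stronger inhibition), compound 3 gives 120 nM. Among the three measured compounds this is the second highest number: compound 1 `CCCc1cc(N)c2cc(NC(=O)/C=C/c3ccc(N)cc3)ccc2n1` gives 190 nM in this assay, and the step of a 1.6-fold lower number from compound 1 to compound 3 (0.20 log units; within the scatter) is within the scatter, whereas compound 2 `CCCc1cc(N)c2cc(NC(=O)/C=C/c3ccc(C(C)C)cc3)ccc2n1` gives 2.9 nM, and the step of a 41-fold higher number from compound 2 to compound 3 (1.62 log units; beyond the scatter) is large.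

Compound 4 `CCCc1cc(N)c2cc(NC(=O)/C=C/c3ccc(Cl)c(Cl)c3)ccc2n1` differs from compound 3 in one place: 3,4-dichlorophenyl in place of 2-chlorophenyl on a double-bonded chain carbon bound to a double-bonded chain carbon.

Within the data shown here, two measured steps bear on this. The step of a 66-fold lower number from compound 1 to compound 2 (1.82 log units; beyond the scatter) shows that the group on the aromatic ring of the cinnamamide governs the read-out strongly, and the step of a 41-fold higher number from compound 2 to compound 3 (1.62 log units; beyond the scatter) shows that moving from 4-isopropylphenyl to 2-chlorophenyl costs most of that gain. Among the measured compounds shown here, compound 4 keeps chlorine but places two of them as 3,4-dichlorophenyl; no measured compound shows exactly this pattern, so the direction rests on the ring-substitution sensitivity seen between compound 1, compound 2 and compound 3.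

A lower number than compound 3 is expected for compound 4, with the step of a 6.0-fold lower number from compound 3 to compound 4 (0.78 log units; beyond the scatter) estimated, giving an expected value of 20 nM in this assay, within a range from 4 nM to 100 nM.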

Compound 4, half-maximal inhibitory concentration: 60 nM
Compound 4: the middle estimate sits 3.0-fold (0.48 log units) below what was measured; low and high end bracket the measured number.
By their numbers in this assay, from the lowest: compound 2; then compounds 4, 3 and 1 (each within the scatter of the next, the first and the last beyond it).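

In this assay, exchanging 2-chlorophenyl for 3,4-dichlorophenyl gives (a 2.0-fold lower number from compound 3 to compound 4 (0.30 log units; within the scatter)), so these two chlorinated rings cannot be told apart on this read-out, and the 3,4-dichlorophenyl group stays far from the 4-isopropylphenyl group of the best compound in the set (a 21-fold higher number from compound 2 to compound 4 (1.32 log units; beyond the scatter)). Against the 4-aminophenyl group, however, 3,4-dichlorophenyl is the first chlorinated ring to separate beyond the scatter, if only modestly (a 3.2-fold lower number from compound 1 to compound 4 (0.50 log units; beyond the scatter)), a separation that compound 3 did not show. No evidence is available on the reason for any of these differences.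

The compounds shown leave open whether the low number of compound 2 belongs to the isopropyl group alone or would also come with a tert-butyl or cyclopentyl group on the same phenyl ring. Compound 3 and compound 4 differ both in the number of chlorines and in where they stand, so a 4-chlorophenyl or 3-chlorophenyl group would be needed to separate those two changes.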